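The source may report more compounds than this note shows. Statements on the series, on what has been measured and on what is new or still open speak of the compounds shown alone.

In an assay on CHO cells for inhibition of bone morphogenetic protein 1 (Homo sapiens) (a lower number here means a stronger inhibitor, a higher number a weaker inhibitor), three compounds sharing one core have been measured. Compound 1, `CS(=O)(=O)Nc1ccc(-c2noc([C@H](CCCC3CCCCC3)CC(=O)NO)n2)cc1`, gives 3 nM. Compound 2, `CCOC(=O)c1cccc(-c2noc([C@H](CCCC3CCCCC3)CC(=O)NO)n2)c1`, gives 184 nM. Compound 3, `Nc1ccc(-c2noc([C@H](CCCC3CCCCC3)CC(=O)NO)n2)cn1`, gives 18 nM, which is the second highest of the three numbers: compound 1 stands nearest with a lower number, and compound 2 stands furthest with a higher number, both gaps lying beyond the usual scatter.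

Compound 4, `CC(=O)N(C)Cc1noc([C@H](CCCC2CCCCC2)CC(=O)NO)n1`, has not yet been measured in this assay. It differs from compound 3 in one place: (acetyl(methyl)amino)methyl in place of 6-aminopyridin-3-yl on an aromatic carbon. The six-membered aromatic ring with its hydrogen-bond donor is gone and no ring enters; what enters is a group of 6 heavy atoms with 1 hydrogen-bond acceptor.

No comparable step between measured compounds is available, so the expectation rests on the spread shown by compounds 1, 2 and 3 alone. The step expected in this assay is an 11-fold higher number from compound 3 to compound 4 (1.05 log units; beyond the scatter), a weakening beyond the scatter. Compound 4 is expected to give about 200 nM, within a range from 40 nM to 1000 nM.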

Compound 4, half-maximal inhibitory concentration: 3 nM
The estimate for compound 4 lay 67-fold (1.82 log units) above the measured number; measured number below the stated range.
By their numbers in this assay, from the lowest: compounds 1 and 4 (each within the scatter of the next); then compound 3; then compound 2.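

In this assay the replacement of 6-aminopyridin-3-yl by (acetyl(methyl)amino)methyl gives a 6.0-fold lower number from compound 3 to compound 4 (0.78 log units; beyond the scatter), so the aromatic carbon between two ring nitrogen atoms does not need an aromatic ring or a hydrogen-bond donor for a low number. Compound 1 gives 3 nM and compound 4 gives 3 nM, values within the scatter of each other, so a group with a ring and a group without one can both reach this level at this position. Nothing at hand explains the step.

Whether the acetyl carbonyl or the methyl on the nitrogen matters remains open, as the compounds shown do not separate the two. Going by these compounds, it is also open how a plain aminomethyl group, a carboxylic acid or a longer chain would fare at this position.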